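A few compounds are considered here, and "the series" means these few. Any claim that something is new, unique, unknown or untested is made for them only; others in the source may bear on it.

Compound 1 `N=C(NCc1ccc(O)cc1)[C@@H]1CCC(=O)N1Cc1ccccc1` gives 37.6% in a functional assay on SH-SY5Y cells (Homo sapiens) for cytotoxicity, read by MTT assay, with stated times of 8 h, 30 min and 12 h, tested at 5 uM; a higher number here means a stronger effect of the compound at the concentration tested, a lower number a weaker effect.
Compound 2 `N=C(NCc1ccc(O)cc1)[C@@H]1CCC(=O)N1Cc1ccccc1[N+](=O)[O-]` gives 30.4% in this assay.
Compound 3 `N=C(NCc1ccc(O)cc1)[C@@H]1CCC(=O)N1Cc1ccc([N+](=O)[O-])cc1` gives 34.5% in this assay.

Among these three numbers compound 3 stands second highest, yet all three lie close together. The step of a number 3.1 percentage points lower from compound 1 to compound 3 (within the scatter) and the step of a number 4.1 percentage points higher from compound 2 to compound 3 (within the scatter) are both within the usual scatter, so none of the three compounds can be called stronger or weaker than another on this evidence.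

The compound to be measured next is compound 4 `N=C(NCc1ccc(O)cc1)[C@@H]1CCC(=O)N1Cc1ccc(F)cc1`. It differs from compound 3 in one place: fluoro in place of nitro on an aromatic carbon. The measured steps that bear on this position are those that put a nitro group onto a hydrogen-bearing aromatic carbon of the same benzyl group: a number 3.1 percentage points lower from compound 1 to compound 3 (within the scatter) at this very position and a number 7.2 percentage points lower from compound 1 to compound 2 (within the scatter) at a different one. Both were within the scatter. Going by the values given here, no measured pair shows what a fluoro group does here, so the expectation rests only on the observation that changing this position has so far not moved the read-out beyond its noise.

The estimate for compound 4 is therefore 35% in this assay, within a range from 25% to 45%, which means an expected step of a number 0.5 percentage points higher from compound 3 to compound 4 (within the scatter), within the scatter.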

Compound 4, a percentage reported as activity, at one concentration (the size of the read-out at that concentration, not a potency): 48.6%
The estimate for compound 4 lay 13.6 percentage points below the measured number; the whole stated range lies below it.
By their numbers in this assay, from the lowest: compounds 2, 3 and 1 (each within the scatter of the next); then compound 4.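

Fluoro in place of nitro on this aromatic carbon, para to a large group, gives a number 14.1 percentage points higher from compound 3 to compound 4 (beyond the scatter) in this assay, so this position can move the read-out after all, depending on which group sits there. Fluoro in place of hydrogen at the same carbon gives a number 11 percentage points higher from compound 1 to compound 4 (beyond the scatter) and so also lies beyond the scatter, whereas neither nitro compound could be told apart from the unsubstituted compound 1; the change to 4-fluorophenyl from 2-nitrophenyl gives a number 18.2 percentage points higher from compound 2 to compound 4 (beyond the scatter) as well, which leaves compound 4 clearly above the other three at this single concentration. No measurement shown here explains why fluoro differs from both hydrogen and nitro at this place.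

Going by these compounds alone, with only one fluoro compound, it remains open whether the rise belongs to fluoro alone or would also appear with chloro, methoxy or an amine at the same carbon. As far as these compounds go, it is equally open whether fluoro would give a similar number at the place the nitro group holds in compound 2, and whether the difference would persist at other concentrations.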